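Amide Nitrogen Substituents and Cell Viability

The compounds below may be only part of what the source reports. "The series", "measured", "known", "first", "only" and "open" are said of these compounds alone.

Measured compounds:
compound 1, `COc1cc2c(cc1O)CCC(C)(CC(=O)N[C@@H](C)C(=O)O)O2`, gives 100% in an ADME assay on SH-SY5Y cells (Homo sapiens) for cytotoxicity, read by MTT assay, with a stated time of 24 h, tested at 25 uM; a higher number here means a weaker effect of the compound at the concentration tested, a lower number a stronger effect
compound 2, `COc1cc2c(cc1O)CCC(C)(CC(N)=O)O2`, gives 100% in this assay

Compound 2 stands level with compound 1 on the numbers shown, both compounds leaving the cells fully viable at the concentration tested. Going by the values given here, the only measured step, no change at the digits printed from compound 1 to compound 2 (within the scatter), involved exchanging the group on the amide-type nitrogen and left the read-out unchanged within the scatter. Compound 3, `COc1cc2c(cc1O)CCC(C)(CC(=O)N[C@@H](CCC(N)=O)C(=O)O)O2`, differs from compound 2 in exactly that position: 3-carbamoyl-1-carboxypropyl in place of hydrogen on an amide-type nitrogen. Among the compounds with values here, the step bearing on this change is therefore the one from compound 1 to compound 2, which was flat, and it involved the same amide-type nitrogen carrying an amino-acid-derived substituent. Within the data shown here, nothing in the two measured values suggests that a substituent on this nitrogen moves the read-out, although only two compounds support that view. Compound 3 is accordingly expected to show no step beyond the scatter, no change at the digits printed from compound 2 to compound 3 (within the scatter), and the estimated value for compound 3 is 100%, with a range from 85% to 100%.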

Compound 3, a percentage reported as activity, at one concentration (the size of the read-out at that concentration, not a potency): 91.8%
Estimate against measurement, compound 3: 8.2 percentage points above; measured number inside the range.
By their numbers in this assay, from the lowest: compounds 3, 1 and 2 (each within the scatter of the next).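

In this assay, the 3-carbamoyl-1-carboxypropyl group on the amide-type nitrogen gives a number 8.2 percentage points lower from compound 2 to compound 3 (within the scatter), so a second amino-acid-derived substituent at this nitrogen also leaves the read-out within the scatter of the unsubstituted amide. Carbamoylmethyl in place of hydrogen on a saturated chain carbon, two bonds along the chain from an amide-type nitrogen and a carbonyl carbon, gives a number 8.2 percentage points lower from compound 1 to compound 3 (within the scatter), which extends the flat picture from the nitrogen itself to the side chain of its substituent, though on the strength of this single pair alone. Nothing available bears on why either step has the size it has.

The substituents shown on this nitrogen are limited to hydrogen, 1-carboxyethyl and 3-carbamoyl-1-carboxypropyl, all but the first of them carrying a carboxylic acid, so it remains open how the read-out would stand with a methyl ester in place of that acid or with a side chain ending in a primary amine. A phenyl ring or a longer alkyl chain on the same nitrogen is equally untested by these compounds, and so is any replacement of the terminal carbamoyl by a carboxylic acid.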